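Fluoro in place of methoxy: compound 3 to compound 4

This account rests on a few compounds, and the source may have more. Where it says the series, first, only, none or still open, it means among the compounds named here.

Measured in a functional assay on MCF7 cells (Homo sapiens) for antiproliferative activity, read by luminescence and CellTiter-Glo, with a stated time of 48 h; a lower number here means a stronger inhibitor, a higher number a weaker inhibitor:
Compound 1 `O=C1C=CC[C@H]([C@H]2C[C@@H]2c2ccccc2)O1`: 48200 nM
Compound 2 `COc1ccc(/C=C/[C@H]2CC=CC(=O)O2)cc1`: > 100000 nM (a limit of the assay, not a number)
Compound 3 `COc1ccc(/C=C/[C@@H]2CC=CC(=O)O2)cc1`: 88700 nM

In this assay compound 3 gives 88700 nM. Compound 1, at 48200 nM, lies within the usual scatter of that value. Compound 2 is reported only as a limit.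

Compound 4 `O=C1C=CC[C@@H](/C=C/c2ccc(F)cc2)O1` departs from compound 3 by one exchange, (fluoro in place of methoxy on an aromatic carbon), which puts fluoro in place of methoxy on an aromatic carbon. Within the data shown here, the one measured step is an at least 1.1-fold lower number from compound 2 to compound 3 (0.05 log units; that floor lies within the scatter). Among the measured compounds shown here, it concerns only (the fact that compounds 2 and 3 differ only in the configuration as drawn), so no measured step gives a size for this exchange. With compound 3 at 88700 nM as the starting point, no change beyond the scatter is expected in this assay, and no direction can be assigned. The expected step is a 1.3-fold lower number from compound 3 to compound 4 (0.10 log units; within the scatter). For compound 4 the estimated value is 70000 nM, with an expected range of 25000 nM to 150000 nM.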

Compound 4, half-maximal inhibitory concentration: > 100000 nM
Compound 4: only a limit was reported (the forecaster's own chance of this, stated with the estimate: 25%); middle value at least 1.4-fold (0.15 log units) away from the limit.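

In this assay compound 4 is reported only as a limit, > 100000 nM, and not as a number. Fluoro in place of methoxy on the aromatic carbon gives an at least 1.1-fold higher number from compound 3 to compound 4 (0.05 log units; that floor lies within the scatter), the first step shown at this position. It shows that this exchange does not bring a lower number than methoxy, but it gives only a floor, so the real size of the step stays unknown: the limit of > 100000 nM in this assay, at which 2 of the 4 values shown sit.

The compounds shown leave open whether an amine, a carboxylic acid or a longer chain on this aromatic carbon would give a number clearly lower than that of compound 3, at 88700 nM. They also leave open whether the configuration as drawn at the saturated ring carbon would matter with fluoro on the aromatic ring.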